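Adding a nitro group to compound 3

This account rests on a few compounds, and the source may have more. Where it says the series, first, only, none or still open, it means among the compounds named here.

In a physicochemical assay for solubility, read by HPLC, at pH 7.4 (on this read-out higher numbers stand for higher solubility and lower numbers for lower solubility), three related compounds have been measured so far. Compound 1 `CCCCCCCc1cc(=O)c2cc([N+](=O)[O-])ccc2[nH]1` gives < 5000 nM, which is a limit of the assay and not a number. Compound 2 `CCCCCCCc1[nH]c2ccc([N+](=O)[O-])cc2c(=O)c1C(=O)O` gives 15000 nM, and compound 3 `CCCCCCCc1[nH]c2ccccc2c(=O)c1C(N)=O` gives 5000 nM, so compound 3 holds the lower of the two actual numbers.

The next structure is compound 4 `CCCCCCCc1[nH]c2ccc([N+](=O)[O-])cc2c(=O)c1C(N)=O`, which has nitro in place of hydrogen on an aromatic carbon of compound 3: nitro in place of hydrogen on an aromatic carbon. Going by the values given here, no measured step shows this change directly. Among the compounds with values here, the only step available is an at least 3.0-fold higher number from compound 1 to compound 2 (0.47 log units; beyond the scatter), and there carboxy enters, not nitro, on a core that already carries nitro. Its size therefore cannot simply be carried over to the new change.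

With no measured sign of a shift in either direction, the expectation stays close to compound 3 at 5000 nM, and no step beyond the scatter is expected. In this assay the estimated step is no change at the digits printed from compound 3 to compound 4 (within the scatter). Compound 4 may also be reported only as a limit, given (the limit of < 5000 nM in this assay, at which 1 of the 3 values shown sits). The estimate for compound 4 is 5000 nM, with an expected range from 2500 nM to 10000 nM.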

Compound 4, solubility: 15000 nM
For compound 4 the middle estimate is 3.0-fold (0.48 log units) below the measured one; the measured number lies above the stated range.
By their numbers in this assay, from the lowest: compound 3; then compounds 2 and 4 (each within the scatter of the next).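

In this assay, going by these compounds alone, nitro in place of hydrogen on an aromatic carbon now has a measured step of its own, one that no earlier pair could show, and this step lies beyond the usual scatter: a 3.0-fold higher number from compound 3 to compound 4 (0.48 log units; beyond the scatter). With nitro on the core, amino in place of hydroxy on a carbonyl carbon gives no change at the digits printed from compound 2 to compound 4 (within the scatter), so carbamoyl and carboxy cannot be told apart here, while carbamoyl as a new group on the core gives an at least 3.0-fold higher number from compound 1 to compound 4 (0.47 log units; beyond the scatter). Compound 1 is reported only as a limit of the assay and not as a number: the limit of < 5000 nM in this assay, at which 1 of the 4 values shown sits.

The compounds shown cover a single group at this place on the six-membered aromatic ring, so it remains open how an amine or a nitrile there would read, and how a shorter chain in place of the shared chain would change the picture. Also open, from the compounds shown here alone, is whether nitro gives a step of the same size when a carboxylic acid, rather than the carbamoyl of compound 3, stands on the core.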